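The compounds below may be only part of what the source reports. "The series", "measured", "known", "first", "only" and "open" are said of these compounds alone.

Of the compounds shown here, three with a shared core have been read in an ADME assay (liver) for metabolic stability, with Liver microsome (Rattus norvegicus) as the target, using microsomes and NADPH, with a stated time of 30 min, tested at 1 uM (on this read-out higher numbers stand for fast clearance and lower numbers for slow clearance), and they differ at a single aromatic carbon. Compound 1 `COc1cc(C(O)(C(F)(F)F)C(F)(F)F)cnc1N1CCN(S(=O)(=O)c2ccc(N)nc2)CC1`, with methoxy at that place, is reported as < 14 mL.min-1.g-1, which is a limit of the assay and not a number. Compound 2 `Nc1ccc(S(=O)(=O)N2CCN(c3ncc(C(O)(C(F)(F)F)C(F)(F)F)cc3C#CCCO)CC2)cn1`, with 4-hydroxybut-1-yn-1-yl, gives 68 mL.min-1.g-1. Compound 3 `Nc1ccc(S(=O)(=O)N2CCN(c3ncc(C(O)(C(F)(F)F)C(F)(F)F)cc3-c3ccoc3)CC2)cn1`, with furan-3-yl, gives 57 mL.min-1.g-1, so it stands within the scatter of compound 2. Replacing methoxy produced clear steps, an at least 4.8-fold higher number from compound 1 to compound 2 (0.68 log units; beyond the scatter) and an at least 4.0-fold higher number from compound 1 to compound 3 (0.60 log units; beyond the scatter), but both start from a limit and so give only a minimum size. The step that bears most directly on what follows exchanged one of these replacement groups for the other, and a 1.2-fold lower number from compound 2 to compound 3 (0.08 log units; within the scatter) stayed within the scatter.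

Compound 4 `Nc1ccc(S(=O)(=O)N2CCN(c3ncc(C(O)(C(F)(F)F)C(F)(F)F)cc3-c3cccc(F)c3)CC2)cn1` has 3-fluorophenyl in place of furan-3-yl on an aromatic carbon, (3-fluorophenyl in place of furan-3-yl on an aromatic carbon). Methoxy is not involved in this change, so the relevant precedent is the small step between compound 2 and compound 3, a 1.2-fold lower number from compound 2 to compound 3 (0.08 log units; within the scatter). On that basis, no step beyond the scatter is expected in this assay, and the expected step is a 1.1-fold higher number from compound 3 to compound 4 (0.04 log units; within the scatter). The estimated value for compound 4 is 62 mL.min-1.g-1, with an expected range of 30 mL.min-1.g-1 to 125 mL.min-1.g-1.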

Compound 4, intrinsic clearance in microsomes: 52 mL.min-1.g-1
Estimate against measurement, compound 4: 1.2-fold (0.08 log units) above; low and high end bracket the measured number.
By their numbers in this assay, from the lowest: compounds 4, 3 and 2 (each within the scatter of the next). At a limit, below all of these: compound 1.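

In this assay, the exchange at this aromatic carbon of a five-membered aromatic ring with 1 hetero atom for a six-membered aromatic ring of carbon only, bearing fluorine, leaves the number within the scatter: a 1.1-fold lower number from compound 3 to compound 4 (0.04 log units; within the scatter), and likewise a 1.3-fold lower number from compound 2 to compound 4 (0.12 log units; within the scatter), so compound 2, compound 3 and compound 4 cannot be told apart although their groups differ in ring size, in hydrogen-bond acceptors and, for compound 2, in having an open chain instead of a ring. Set against methoxy, the new group also gives a step beyond the scatter, an at least 3.7-fold higher number from compound 1 to compound 4 (0.56 log units; beyond the scatter), so all three replacements shown now stand clear of compound 1. The size of that step is only a minimum, because compound 1 is reported at a limit: the limit of < 14 mL.min-1.g-1 in this assay, at which 1 of the 4 values shown sits.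

The compounds shown leave open whether any group other than methoxy at this place can return the number towards that of compound 1, for instance ethoxy, an amine or a carboxylic acid. They also leave open whether moving the fluorine elsewhere on the phenyl ring, or replacing it with chlorine, would matter here.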